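From Ethyl to Isopropyl in a Growth Inhibition Series

The source may report more compounds than this note shows. Statements on the series, on what has been measured and on what is new or still open speak of the compounds shown alone.

Measured in a functional assay on A549 cells (Homo sapiens) for inhibition, read by sulforhodamine B assay, with a stated time of 48 h; on this read-out lower numbers stand for stronger inhibition of growth and higher numbers for weaker inhibition of growth:
- compound 1 `CCN(C(=O)c1cc(C(C)C)c(O)cc1O)c1ccc(NC(=O)CCCCCCC(=O)NO)cc1`: 5630 nM
- compound 2 `CC(C)c1cc(C(=O)Nc2cccc(NC(=O)CCCCCCC(=O)NO)c2)c(O)cc1O`: > 10000 nM (a limit of the assay, not a number)

Among the compounds with values here, compound 1, at 5630 nM, holds the only true number in this small set. Compound 2 reports only the limit > 10000 nM. Within the data shown here, no step between measured compounds is available.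

Compound 3 `CC(C)c1cc(C(=O)N(c2ccc(NC(=O)CCCCCCC(=O)NO)cc2)C(C)C)c(O)cc1O` has not yet been measured. It keeps the rest of compound 1 and carries one change: methyl in place of hydrogen on a saturated chain carbon bound to an amide-type nitrogen and a saturated chain carbon. In other words, ethyl gives way to isopropyl on the amide-type nitrogen.

Among the measured compounds shown here, with no measured step as a guide, the estimated step of a 1.1-fold lower number from compound 1 to compound 3 (0.05 log units; within the scatter) in this assay is expected to stay within the usual scatter, with no firm direction. Compound 3 is expected at 5000 nM, with an estimated range from 2000 nM to 12000 nM.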

Compound 3, concentration for 50% growth inhibition: > 10000 nM
Compound 3 ended at the assay's limit (the forecaster's own chance of this, stated with the estimate: 20%); middle value at least 2.0-fold (0.30 log units) from the limit.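

In this assay, within the data shown here, the change from ethyl to isopropyl on the amide-type nitrogen gives an at least 1.7-fold higher number from compound 1 to compound 3 (0.24 log units; that floor lies within the scatter), and this is the first reading at this position. Compound 3 sits at a limit of the assay (> 10000 nM), which is not a number. Only the floor of the step can be read, and that floor does not establish a real loss of growth inhibition, because the read-out stops at the limit: the limit of > 10000 nM in this assay, at which 2 of the 3 values shown sit.

The compounds shown leave open how far past the limit compound 3 actually lies. They also leave open how a longer chain such as n-propyl, or a ring such as cyclopropyl, on the amide-type nitrogen would read in this assay.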